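Swapping the benzyl arm for a branched alkyl chain

The source may report more compounds than this note shows. Statements on the series, on what has been measured and on what is new or still open speak of the compounds shown alone.

Compound 1 `Fc1ccc(Cn2ccc3nc(-c4ccccc4)nc-3c2)cc1` is the starting point. In an ADME assay on MDBK cells (Bos taurus) for cytotoxicity (a lower number here means that less compound is tolerated, a higher number that more compound is tolerated), compound 1 gives > 100000 nM, which is a limit of the assay rather than a number. Two comparison compounds are known. Compound 2 `CC(C)(C)c1ccc(Cn2ccc3nc(-c4ccccc4)nc-3c2)cc1` gives 22000 nM, and the step of an at least 4.5-fold lower number from compound 1 to compound 2 (0.65 log units; beyond the scatter) came with tert-butyl in place of fluoro on an aromatic carbon. Compound 3 `O=C(O)c1ccc(Cn2ccc3nc(-c4ccccc4)nc-3c2)cc1` gives > 100000 nM, again a limit of the assay. The step of an at least 4.5-fold higher number from compound 2 to compound 3 (0.65 log units; beyond the scatter) came with carboxy in place of tert-butyl on an aromatic carbon, while a step that the two limits leave unreadable from compound 1 to compound 3 cannot be sized, since both values sit at the limit of > 100000 nM in this assay, at which 2 of the 3 values shown sit.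

Compound 4 `CCC(CC)Cn1ccc2nc(-c3ccccc3)nc-2c1` is not yet measured. It differs from compound 1 by pentan-3-yl in place of 4-fluorophenyl on a saturated chain carbon bound to an aromatic nitrogen. Among the measured compounds shown here, none of the measured steps touches this position; they all vary a group on the aromatic ring that here disappears entirely. For the measured compounds named here, the only guidance is that the larger hydrocarbon group in compound 2 lowered the tolerated number, whereas the carboxy group in compound 3 kept it at the limit. Compound 4 is therefore expected to land near 60000 nM, in the range 20000 nM to 200000 nM, which means an expected step of an at least 1.6-fold lower number from compound 1 to compound 4 (0.22 log units; that floor lies within the scatter).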

Compound 4, half-maximal cytotoxic concentration: > 100000 nM
Compound 4 was reported as a limit; the forecaster's own chance of this, stated with the estimate: 50%; at least 1.6-fold (0.22 log units) between middle value and limit.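

In this assay compound 4 gives > 100000 nM as a limit of the assay. Among the compounds shown here, no step from compound 1 to compound 4 can be read, because both compounds sit at the same limit: the limit of > 100000 nM in this assay, at which 3 of the 4 values shown sit. The compounds shown leave open whether pentan-3-yl in place of 4-fluorophenyl changes the tolerated concentration at all.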